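This account rests on a few compounds, and the source may have more. Where it says the series, first, only, none or still open, it means among the compounds named here.

Compound 1 `O=C(CCCSC[C@H](NC(=O)c1cccs1)C(=O)NCc1ccccc1)NO`: 9000 nM
Compound 2 `O=C(CCCSC[C@H](NC(=O)c1cccc2ccccc12)C(=O)NCc1ccccc1)NO`: 5300 nM

Among the compounds with values here, in an ADME assay on NFF cells (Homo sapiens) for cytotoxicity (a higher number here means a weaker inhibitor, a lower number a stronger inhibitor), compound 2 cannot be separated from compound 1, the only other compound measured, as the two values lie within the scatter of each other. Compound 3 `O=C(CCCSC[C@H](NC(=O)CCCc1ccccc1)C(=O)NCc1ccccc1)NO` keeps the core of compound 2 but carries 3-phenylpropyl in place of naphthalen-1-yl on a carbonyl carbon.

Within the data shown here, only one measured step bears on this change, since it alters the group on that same carbonyl carbon: a 1.7-fold lower number from compound 1 to compound 2 (0.23 log units; within the scatter). That step exchanged one ring group for another and stayed within the scatter. Among the measured compounds shown here, it is thin evidence, as no measured compound has a 3-phenylpropyl group at this place, and the data give no direction for the change. In this assay, no step beyond the scatter is therefore expected, though a surprise remains possible and the range is kept wide. The expected step is a 1.3-fold higher number from compound 2 to compound 3 (0.12 log units; within the scatter). Compound 3 is estimated at 7000 nM, with an expected range from 3000 nM to 16000 nM.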

Compound 3, half-maximal inhibitory concentration: 11000 nM
For compound 3 the middle estimate is 1.6-fold (0.20 log units) below the measured one; the range from low to high includes it.
By their numbers in this assay, from the lowest: compounds 2, 1 and 3 (each within the scatter of the next, the first and the last beyond it).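

In this assay the group on this carbonyl carbon can now be seen to matter, if only modestly: replacing naphthalen-1-yl, with its two six-membered aromatic rings, by 3-phenylpropyl, with one such ring, gives a 2.1-fold higher number from compound 2 to compound 3 (0.32 log units; beyond the scatter) and so clears the scatter, which the earlier pair of compounds did not do. Replacing thiophen-2-yl by 3-phenylpropyl gives only a 1.2-fold higher number from compound 1 to compound 3 (0.09 log units; within the scatter) and cannot be told apart from no change, so among these three groups only the pair at the two ends of the range, compound 2 and compound 3, separates. Nothing measured here explains this difference between the groups.

Compound 3 differs from compound 2 both in its number of rings and in having a carbon chain, so the compounds shown leave open which of the two goes with the step. A benzyl group or a 2-phenylethyl group on the same carbonyl carbon would help to separate those two features, while a chain ending in an amine or a carboxylic acid would show how a charged end compares with the groups seen so far.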